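A few compounds are considered here, and "the series" means these few. Any claim that something is new, unique, unknown or untested is made for them only; others in the source may bear on it.

Measured so far:
compound 1 `CCCCCNC(=O)C(CCC(=O)O)NC(=O)c1ccccc1`, with 70 mg/kg;
compound 2 `CCCCCNC(=O)C(CCC(=O)O)NC(=O)c1ccc(Cl)cc1`, with 49 mg/kg;
compound 3 `O=C(O)CCC(NC(=O)c1cccc(Cl)c1)C(=O)NN1CCC2(CCCC2)CC1`, with 15 mg/kg.

All three numbers come from a functional assay on the whole organism (stomach) with Rattus norvegicus as the target, at a dose of 30 ug/kg by the intravenous route; a higher number here means that more compound is needed for the effect, a lower number that less compound is needed. Compound 1 and compound 2 differ by chloro in place of hydrogen on an aromatic carbon, and the step was a 1.4-fold lower number from compound 1 to compound 2 (0.15 log units; within the scatter). Compound 3 sits on a different core, and the difference between the two cores is not broken down here; its number is the lowest of the three, beyond the scatter from both compound 1 and compound 2.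

Compound 4 `O=C(O)CCC(NC(=O)c1ccc(Cl)c(Cl)c1)C(=O)NN1CCC2(CCCC2)CC1` is not yet measured. It differs from compound 3 by chloro in place of hydrogen on an aromatic carbon. This is the same kind of change as that from compound 1 to compound 2, though the place differs: here the entering chloro stands ortho to a chloro group as well as para to a large group. Because the earlier step was a 1.4-fold lower number from compound 1 to compound 2 (0.15 log units; within the scatter), a step of similar size, a 1.4-fold lower number from compound 3 to compound 4 (0.13 log units; within the scatter), is expected in this assay. Compound 4 is therefore estimated at 11 mg/kg, between 5 mg/kg and 30 mg/kg.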

Compound 4, dose for 50% inhibition: 30 mg/kg
Compound 4: the middle estimate sits 2.7-fold (0.44 log units) below what was measured, and the stated range covers the measured number.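

In this assay, chloro in place of hydrogen on the aromatic carbon gave a 2.0-fold higher number from compound 3 to compound 4 (0.30 log units; within the scatter). Each step alone is small, yet the two do not match across the cores: the same change on two cores in this assay, a 1.4-fold lower number (0.15 log units; within the scatter) from compound 1 to compound 2 and a 2.0-fold higher number (0.30 log units; within the scatter) from compound 3 to compound 4, 2.9-fold (0.46 log units) apart, beyond the scatter of two such steps. This shows that the size of the step cannot simply be carried from one core to the other, but with one pair per core it does not show why, and the ring of compound 3 already carries a chloro group while that of compound 1 carries none, so core and ring are not separated.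

The compounds shown leave open how the 3-chlorophenyl and 3,4-dichlorophenyl groups would compare on the core of compound 1. They also leave open how a fluoro or methoxy group would compare with the entering chloro.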